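This account rests on a few compounds, and the source may have more. Where it says the series, first, only, none or still open, it means among the compounds named here.

Working notes on the series. In a functional assay for inhibition, tested at 20 ug/mL (on this read-out lower numbers stand for a weaker effect and higher numbers for a stronger effect at the one concentration tested), compound 2 `COc1cc(-c2cc(-c3cc(C(C)C)c(O)cc3C)[nH]c(=O)c2C#N)ccc1O` gives 26%; compound 1 `COc1cccc(-c2cc(-c3cc(C(C)C)c(O)cc3C)[nH]c(=O)c2C#N)c1` gives 22%, and the step of a number 4 percentage points higher from compound 1 to compound 2 (within the scatter) places the two within the scatter of each other. Compound 3 `Cc1cc(O)c(C(C)C)cc1-c1cc(-c2ccco2)c(C#N)c(=O)[nH]1` differs from compound 2 by furan-2-yl in place of 4-hydroxy-3-methoxyphenyl on an aromatic carbon. For the measured compounds named here, no measured step replaces the 4-hydroxy-3-methoxyphenyl; the only step on record, hydroxy in place of hydrogen, was within the scatter, so it gives no footing for a shift in this assay. The expected step is therefore a number 4 percentage points lower from compound 2 to compound 3 (within the scatter), none beyond the scatter. For compound 3 the estimate is 22%, in the range 6% to 38%.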

Compound 3, a percentage reported as inhibition, at one concentration (the size of the read-out at that concentration, not a potency): 26%
Estimate against measurement, compound 3: 4 percentage points below; low and high end bracket the measured number.
By their numbers in this assay, from the lowest: compounds 1, 2 and 3 (each within the scatter of the next).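

On the carbon opposite the ring nitrogen, replacing the whole aryl group with furan-2-yl gives no change at the digits printed from compound 2 to compound 3 (within the scatter) and a number 4 percentage points higher from compound 1 to compound 3 (within the scatter) in this assay. The earlier step changed only a hydroxy on the aryl group, whereas these steps show that a five-membered aromatic ring with one hetero atom can stand in place of either six-membered carbon ring without a shift beyond the scatter at the one concentration tested. No evidence available here bears on this result.

On these data alone, it remains open whether an amine, a carboxylic acid or a longer chain on this carbon would give a number beyond the scatter of these three compounds.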